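Exchanging the Biaryl Substituent: Cytotoxicity Expectation for Compound 4

This account rests on a few compounds, and the source may have more. Where it says the series, first, only, none or still open, it means among the compounds named here.

Three compounds have been measured in an ADME assay on HEK293 cells (Homo sapiens) for cytotoxicity, read by CellTiter-Glo and resazurin assay, with a stated time of 72 h; on this read-out lower numbers stand for an effect already at smaller amounts and higher numbers for an effect only at larger amounts of compound:
Compound 1, `CC(C)N(Cc1cccc(OCCCCCC(=O)O)c1)C(=O)c1ccc(-c2cccc(N(C)C)c2)cc1`, gives > 26000 nM, which is a limit of the assay.
Compound 2, `CC(C)COc1cccc(-c2ccc(C(=O)N(Cc3cccc(OCCCCCC(=O)O)c3)C(C)C)cc2)c1`, gives > 26000 nM, which is a limit of the assay.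
Compound 3, `CC(C)N(Cc1cccc(OCCCCCC(=O)O)c1)C(=O)c1ccc(-c2cccc(Br)c2)cc1`, gives > 26000 nM, which is a limit of the assay.

Compound 2 thus stands at the limit shared by every measured value, because of the limit of > 26000 nM in this assay, at which 3 of the 3 values shown sit. The three measured steps, a step that the two limits leave unreadable from compound 1 to compound 2, a step that the two limits leave unreadable from compound 1 to compound 3 and a step that the two limits leave unreadable from compound 2 to compound 3, are each left unreadable by the two limits involved, so none of them shows a size or a direction.

Compound 4, `CC(C)N(Cc1cccc(OCCCCCC(=O)O)c1)C(=O)c1ccc(-c2ccc(Cl)c(Cl)c2)cc1`, is the unmeasured member. Its change from compound 2 is 3,4-dichlorophenyl in place of 3-(isobutoxy)phenyl on an aromatic carbon. The step most closely related is a step that the two limits leave unreadable from compound 2 to compound 3, a change at the same aromatic carbon, yet it carries no readable size. Going by the values given here, no measured step therefore points to any movement in this assay beyond the scatter, in either direction.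

The expectation is that compound 4 again reaches only the limit, with the step that the limit leaves unreadable from compound 2 to compound 4 estimated as essentially flat. Compound 4 is estimated at 30000 nM, within a range from 15000 nM to 60000 nM.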

Compound 4, half-maximal effective concentration: > 26000 nM
Compound 4 ended at the assay's limit; the forecaster's own chance of this, stated with the estimate: 85%; the middle value lies beyond the limit too.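

Compound 4 sits at the same limit as compound 1, compound 2 and compound 3, so no step among these four compounds can be read in size or direction: the limit of > 26000 nM in this assay, at which 4 of the 4 values shown sit.

From the compounds shown here alone, what stays open is where each of the four compounds would give a real value in this assay, and whether their substituents make any difference there.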